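Aryl change on the piperidinyl chain compound

A few compounds are considered here, and "the series" means these few. Any claim that something is new, unique, unknown or untested is made for them only; others in the source may bear on it.

In a functional assay on PC-3 cells (Homo sapiens) for cytotoxicity, read by MTT assay, with stated times of 48 h and 4 h (on this read-out lower numbers stand for stronger inhibition and higher numbers for weaker inhibition), compound 2 (`COc1ccc(/C=C/c2nc(NCCN3CCCCC3)c3cc(Cl)ccc3n2)cc1OC`) gives 21200 nM and stands level with compound 1 (`COc1ccc(/C=C/c2nc(NCCN(C)C)c3cc(Cl)ccc3n2)cc1OC`), which gives 23600 nM on the same read-out. The step between them, a 1.1-fold lower number from compound 1 to compound 2 (0.05 log units; within the scatter) here, is small. Compound 3 (`COc1ccc(/C=C/c2nc(NCCCCN)c3cc(Cl)ccc3n2)cc1OC`) stands at > 100000 nM and this is a limit of the assay, not a number. The steps of an at least 4.2-fold higher number from compound 1 to compound 3 (0.62 log units; beyond the scatter) and an at least 4.7-fold higher number from compound 2 to compound 3 (0.67 log units; beyond the scatter) are the only ones beyond the scatter, and both concern the group on the saturated chain.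

Compound 4 (`O=[N+]([O-])c1ccc(/C=C/c2nc(NCCN3CCCCC3)c3cc(Cl)ccc3n2)cc1`) keeps the chain of compound 2 and differs by 4-nitrophenyl in place of 3,4-dimethoxyphenyl on a double-bonded chain carbon bound to a double-bonded chain carbon with 4-nitrophenyl in place of 3,4-dimethoxyphenyl on a double-bonded chain carbon bound to a double-bonded chain carbon. Within the data shown here, no measured step touches this place, so none of them gives a size or direction for the change. The starting point is therefore the value of compound 2, with a wide margin. The expected step is a 1.1-fold lower number from compound 2 to compound 4 (0.03 log units; within the scatter) and it is estimated to stay within the scatter, with no firm direction. For compound 4 the estimated value is 20000 nM with an expected range from 6000 nM to 70000 nM in this assay as it stands.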

Compound 4, half-maximal inhibitory concentration: > 100000 nM
Compound 4 gave a limit, no number; the forecaster's own chance of this, stated with the estimate: 15%; middle value at least 5.0-fold (0.69 log units) from the limit.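

The aryl group on the double-bonded chain carbon matters in this assay: with the piperidin-1-yl chain held fixed, 4-nitrophenyl in place of 3,4-dimethoxyphenyl gives an at least 4.7-fold higher number from compound 2 to compound 4 (0.67 log units; beyond the scatter). Until now, only changes to the group on the saturated chain had moved the read-out beyond the scatter, and this step shows that the aryl place can do so as well. The full size of the step cannot be read because compound 4 ends at a limit of the assay, not a number: the limit of > 100000 nM in this assay, at which 2 of the 4 values shown sit.

One step both removes the two methoxy groups and brings in the nitro group, so the two changes remain unseparated; 4-methoxyphenyl or 4-aminophenyl on the same carbon would separate them. From the compounds shown here alone, it also remains open whether 4-nitrophenyl has the same effect on the dimethylamino chain of compound 1.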